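Triazole substituent swap: 4-pentylphenyl to 3-chloropropyl

The compounds below may be only part of what the source reports. "The series", "measured", "known", "first", "only" and "open" are said of these compounds alone.

Measured in a functional assay on MCF7 cells (Homo sapiens) for antiproliferative activity, read by MTT assay, with a stated time of 72 h; on this read-out lower numbers stand for stronger inhibition and higher numbers for weaker inhibition:
compound 1 `CCCCCc1ccc(-c2cn(C[C@H](O)[C@H]3OC(=O)C(OCc4ccccc4)=C3OCc3ccccc3)nn2)cc1` gives 9010 nM
compound 2 `O=C1O/C(=C\Cn2cc(-c3cc(C(F)(F)F)cc(C(F)(F)F)c3)nn2)C(OCc2ccccc2)=C1OCc1ccccc1` gives > 100000 nM, a limit of the assay, not a number

For the measured compounds named here, compound 1 holds the only numerical value in this assay; the other entry, compound 2, reaches only a limit. Compound 2 sits at the limit of > 100000 nM in this assay, at which 1 of the 2 values shown sits, so it reports no number at all. Going by the values given here, no pair of measured compounds differs in a single place, so no measured step is available.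

Compound 3 `O=C1O[C@H]([C@@H](O)Cn2cc(CCCCl)nn2)C(OCc2ccccc2)=C1OCc1ccccc1` is not yet measured. It differs from compound 1 by 3-chloropropyl in place of 4-pentylphenyl on an aromatic carbon. The 4-pentylphenyl group leaves and a short 3-chloropropyl chain enters at the same aromatic carbon of the shared core.

Among the compounds with values here, with no measured step to lean on, the expectation rests on compound 1 alone and on the fact that compound 2 reaches only a limit. The step from compound 1 to compound 3 is expected to weaken inhibition beyond the scatter, a 3.9-fold higher number from compound 1 to compound 3 (0.59 log units; beyond the scatter), with a real chance that only a limit is returned. Compound 3 is therefore estimated at 35000 nM, in the range 8000 nM to 150000 nM.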

Compound 3, half-maximal inhibitory concentration: 24500 nM
Beside the measured number, compound 3's estimate is 1.4-fold (0.15 log units) above it; measured number inside the range.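

In this assay, for the compounds shown here, the replacement of 4-pentylphenyl by 3-chloropropyl on an aromatic carbon of the five-membered aromatic ring with 3 nitrogen gives the first measured step at this position: a 2.7-fold higher number from compound 1 to compound 3 (0.43 log units; beyond the scatter). The position therefore keeps a numerical read-out without any ring on this substituent, as compound 3 gives 24500 nM, so inhibition weakens here but is not lost. Compound 2 stays a limit of the assay, not a number, and it differs from the other compounds in more than one place, so it adds no step to this comparison: the limit of > 100000 nM in this assay, at which 1 of the 3 values shown sits.

A single step cannot separate what the aromatic ring of 4-pentylphenyl contributes from what its pentyl chain contributes, nor show whether the chlorine of 3-chloropropyl matters at all. A plain phenyl group, a longer chain ending in chlorine, or a propyl chain ending in an amine at this same aromatic carbon would divide those contributions.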